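Swapping isopropyl for a methoxypropyl chain on the ring nitrogen

The source may report more compounds than this note shows. Statements on the series, on what has been measured and on what is new or still open speak of the compounds shown alone.

Compound 3 `CC(C)[N+]1(C)CCc2c(sc(NC(=O)Nc3ccc(Cl)cc3)c2C(N)=O)C1` carries an isopropyl on the ring nitrogen and in a functional assay (strain AB) with Danio rerio as the target, read by microscopy, with a stated time of 1 h (a higher number here means that more compound is needed for the effect, a lower number that less compound is needed), gives 960 nM. This is the highest of the three numbers measured: compound 1 `CC(C)(C)OC(=O)CCC[N+]1(C)CCc2c(sc(NC(=O)Nc3ccc(Cl)cc3)c2C(N)=O)C1` gives 250 nM in this assay, and compound 2 `C[N+]1(CC2CCC2)CCc2c(sc(NC(=O)Nc3ccc(Cl)cc3)c2C(N)=O)C1` gives 210 nM. Read toward compound 3, the step of a 3.8-fold higher number from compound 1 to compound 3 (0.58 log units; beyond the scatter) and the step of a 4.6-fold higher number from compound 2 to compound 3 (0.66 log units; beyond the scatter) both show that putting isopropyl on that nitrogen in place of a longer group raises the number beyond the scatter.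

Compound 4 `COCCC[N+]1(C)CCc2c(sc(NC(=O)Nc3ccc(Cl)cc3)c2C(N)=O)C1` differs from compound 3 in one place: 3-methoxypropyl in place of isopropyl on an amine nitrogen in a ring. This restores a chain on that nitrogen, as in compound 1 and compound 2, so those two steps bear directly on the change. A step of a 3.2-fold lower number from compound 3 to compound 4 (0.51 log units; beyond the scatter) toward a lower number is expected because a 3.8-fold higher number from compound 1 to compound 3 (0.58 log units; beyond the scatter) ran the opposite way when a chain was replaced by isopropyl. Compound 4 is therefore estimated at 300 nM in this assay, with a range from 120 nM to 800 nM.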

Compound 4, half-maximal effective concentration: 480 nM
Beside the measured number, compound 4's estimate is 1.6-fold (0.20 log units) below it; low and high end bracket the measured number.
By their numbers in this assay, from the lowest: compounds 2, 1, 4 and 3 (each within the scatter of the next, the first and the last beyond it).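

Adding a chain to the ring nitrogen does not by itself clearly separate a compound from the isopropyl compound, since 3-methoxypropyl gives a step that stays inside the scatter (a 2.0-fold lower number from compound 3 to compound 4 (0.30 log units; within the scatter)) in this assay. Compound 4 also cannot be told apart from the tert-butyl ester chain (a 1.9-fold higher number from compound 1 to compound 4 (0.28 log units; within the scatter)), so it lies within the scatter of both compound 1 and compound 3, though those two lie beyond the scatter of each other, and only the cyclobutylmethyl group stands clearly apart from it (a 2.3-fold higher number from compound 2 to compound 4 (0.36 log units; beyond the scatter)). Nothing measured here explains these differences between groups.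

Still open, going by these compounds, is whether the ring in cyclobutylmethyl or the oxygen in 3-methoxypropyl matters, which a plain butyl chain could help to separate. A chain ending in a carboxylic acid or an amine is also untested among the compounds shown, so its place relative to compound 2 and compound 3 remains unknown.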